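The source may hold more compounds than are shown below. What is called first, only, known or untested is meant among the compounds shown, and "the series" means these compounds.

Measured compounds in this study:
Compound 1 `Cc1cccc(/C(N)=N/NC(=S)N2CCSCC2)n1` gives 46.8%.
Compound 2 `N/C(=N\NC(=S)N1CCSCC1)c1ccccn1` gives 72.4%.
Compound 3 `Cc1ccnc(/C(N)=N/NC(=S)N2CCCCCC2)c1` gives 65.4%.

In a functional assay on MCF7 cells (Homo sapiens) for cytotoxicity, read by MTT assay, with a stated time of 72 h, tested at 100 uM (on this read-out lower numbers stand for less inhibition of growth and higher numbers for more inhibition of growth at the one concentration tested), compound 1 stands lowest of the three numbers; compound 3 lies higher and compound 2 higher still, each beyond the scatter. Compound 4 `Cc1cccc(/C(N)=N/NC(=S)N2CCCC2)n1` differs from compound 1 by pyrrolidin-1-yl in place of thiomorpholin-4-yl on a thiocarbonyl carbon. Going by the values given here, no measured step changes the ring on the thiocarbonyl carbon: the single measured step, a number 25.6 percentage points higher from compound 1 to compound 2 (beyond the scatter), concerns a methyl on the aromatic ring, and compound 3 differs from compound 1 in two places at once, so its value shows nothing about the ring swap alone. The change in compound 4 is therefore expected to bring no step beyond the scatter in this assay, in either direction. The estimate for compound 4 is 50%, ranging from 30% to 70%, meaning an expected step of a number 3.2 percentage points higher from compound 1 to compound 4 (within the scatter).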

Compound 4, percent growth inhibition at one concentration: 61.8%
Beside the measured number, compound 4's estimate is 11.8 percentage points below it; measured number inside the range.
By their numbers in this assay, from the lowest: compound 1; then compounds 4, 3 and 2 (each within the scatter of the next, the first and the last beyond it).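

In this assay, going by these compounds alone, the ring on the thiocarbonyl carbon turns out to count: pyrrolidin-1-yl in place of thiomorpholin-4-yl gives a number 15 percentage points higher from compound 1 to compound 4 (beyond the scatter) as the first measured step at this position. The number therefore moves with this position as well as with the methyl on the aromatic carbon, though the step is modest. Nothing at hand accounts for this step. Open, on these data alone, is whether a piperidin-1-yl or morpholin-4-yl ring on the thiocarbonyl carbon would move the number too, and whether the step holds on the core of compound 2.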